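Chloro Substitution Tested on Two Related Cores

The source may report more compounds than this note shows. Statements on the series, on what has been measured and on what is new or still open speak of the compounds shown alone.

Compound 1 `CCCCCCCCCCC(CCO)n1cnc2c(N)ncnc21` gives 2590 nM in a functional assay on HCT-116 cells (Homo sapiens) for antiproliferative activity, read by MTT assay, with a stated time of 48 h; a lower number here means a stronger inhibitor, a higher number a weaker inhibitor. Compound 2 `CCCCCCCCCCC(CCO)n1cnc2c(N)nc(Cl)nc21` carries chloro in place of hydrogen on an aromatic carbon and gives 11800 nM in this assay, so that a 4.6-fold higher number from compound 1 to compound 2 (0.66 log units; beyond the scatter). Compound 3 `CCCCCCCCCCCC(CCO)n1cnc2c(N)ncnc21` differs from compound 1 by methyl in place of hydrogen on a saturated chain carbon, ten or more bonds along the chain from an aromatic nitrogen; in this assay compound 3 gives 13400 nM, so that a 5.2-fold higher number from compound 1 to compound 3 (0.71 log units; beyond the scatter). Compounds 2 and 3 give numbers within the usual scatter of each other.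

Compound 4 `CCCCCCCCCCCC(CCO)n1cnc2c(N)nc(Cl)nc21` has not yet been measured. It differs from compound 3 by chloro in place of hydrogen on an aromatic carbon, the same change that turns compound 1 into compound 2, and this change occurs twice among these four compounds. The expectation for compound 4 rests on that single earlier step: if the chloro change acts on the core of compound 3 as it did on the core of compound 1, the step is expected to be a 4.1-fold higher number from compound 3 to compound 4 (0.61 log units; beyond the scatter), standing beside the earlier 4.6-fold higher number from compound 1 to compound 2 (0.66 log units; beyond the scatter). Because compound 3 already gives 13400 nM, compound 4 is estimated at 55000 nM, with a likely range from 20000 nM to 150000 nM. Among the compounds with values here, with only one prior instance of the change, this estimate is tentative.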

Compound 4, half-maximal inhibitory concentration: 20000 nM
Estimate against measurement, compound 4: 2.8-fold (0.44 log units) above; measured number inside the range.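

In this assay, chloro in place of hydrogen on an aromatic carbon gives a 1.5-fold higher number from compound 3 to compound 4 (0.17 log units; within the scatter), so the step seen on the core of compound 1 did not carry over at the same size to the core of compound 3: the same change on two cores in this assay, a 4.6-fold higher number (0.66 log units; beyond the scatter) from compound 1 to compound 2 and a 1.5-fold higher number (0.17 log units; within the scatter) from compound 3 to compound 4, 3.1-fold (0.48 log units) apart, beyond the scatter of two such steps. The methyl change reads the same way, giving a 1.7-fold higher number from compound 2 to compound 4 (0.23 log units; within the scatter) on the core of compound 2, so its size also differs from core to core: the same change on two cores in this assay, a 5.2-fold higher number (0.71 log units; beyond the scatter) from compound 1 to compound 3 and a 1.7-fold higher number (0.23 log units; within the scatter) from compound 2 to compound 4, 3.1-fold (0.48 log units) apart, beyond the scatter of two such steps. These two comparisons rest on the same four compounds and thus show one departure from simple addition of the two changes, not two independent ones, and they show neither why the steps differ nor how either change would behave on any other core.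

Going by these compounds, it remains open whether the same holds for a longer or shorter chain. On these data alone, it is also open what bromo, fluoro or an amine would do in place of chloro on that carbon between two ring nitrogen atoms.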